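The source may report more compounds than this note shows. Statements on the series, on what has been measured and on what is new or still open speak of the compounds shown alone.

Within the data shown here, in a functional assay on MCF7 cells (Homo sapiens) for antiproliferative activity, read by sulforhodamine B assay, with a stated time of 48 h (on this read-out lower numbers stand for stronger inhibition and higher numbers for weaker inhibition), compound 1 (`COc1ccc(/C=C/C(=O)c2ccccc2-c2ccc(F)cc2)cc1`) gives 120 nM, the higher of the two numbers measured so far. Compound 2 (`COc1ccc(/C=C/C(=O)c2ccccc2-c2ccc(F)cc2)cc1O`) gives 7 nM. Among the measured compounds shown here, the only measured step, with hydroxy in place of hydrogen on an aromatic carbon, is large: a 17-fold lower number from compound 1 to compound 2 (1.23 log units; beyond the scatter). Compound 3 (`CN(C)c1ccc(/C=C/C(=O)c2ccccc2-c2ccc(F)cc2)cc1`) keeps the core of compound 1 but carries dimethylamino in place of methoxy on an aromatic carbon, para to a large group: dimethylamino in place of methoxy on an aromatic carbon. The step to compound 2, a 17-fold lower number from compound 1 to compound 2 (1.23 log units; beyond the scatter), bears on this only loosely. For the measured compounds named here, it shows that one small change can move the number far, but no measured step replaces the methoxy. In this assay no shift beyond the scatter is therefore expected, though the uncertainty stays wide. The expected step is a 1.3-fold higher number from compound 1 to compound 3 (0.10 log units; within the scatter). For compound 3 the estimated value is 150 nM, with an expected range from 40 nM to 600 nM.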

Compound 3, half-maximal inhibitory concentration: 45 nM
Estimate against measurement, compound 3: 3.3-fold (0.52 log units) above; low and high end bracket the measured number.
By their numbers in this assay, from the lowest: compound 2; then compound 3; then compound 1.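

In this assay, among these compounds, the step from methoxy to dimethylamino gives a 2.7-fold lower number from compound 1 to compound 3 (0.43 log units; beyond the scatter) and so shows what the earlier compounds could not: the group para to a large group on this ring is not neutral to change, and the methoxy itself can be replaced without loss. The change is modest, whereas the hydroxy step gave a 17-fold lower number from compound 1 to compound 2 (1.23 log units; beyond the scatter) and remains the larger move among those shown. No measurement here explains why dimethylamino lowers the number.

As far as these compounds go, with one replacement at this carbon, it remains open whether an amino group, methylamino or a ring amine such as morpholine would lower the number further or raise it. From the compounds shown here alone, it is also open whether the hydroxy of compound 2 and the dimethylamino of compound 3 would work together on one ring.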